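A few compounds are considered here, and "the series" means these few. Any claim that something is new, unique, unknown or untested is made for them only; others in the source may bear on it.

Measured in a functional assay on MDA-MB-231 cells (Homo sapiens) for inhibition, read by MTT assay, with a stated time of 72 h; a lower number here means a stronger inhibitor, a higher number a weaker inhibitor:
- compound 1 `CC1=NN(c2ccccc2)C(=O)[C@]12C(=O)C=CC[C@H]2c1cccc(C)c1`: 10300 nM
- compound 2 `CC1=NN(c2ccccc2)C(=O)[C@@]12C(=O)C=CC[C@@H]2c1cccc(C)c1`: 6800 nM
- compound 3 `CC1=NN(c2ccccc2)C(=O)[C@]12C(=O)C=CC[C@@H]2c1cccc(C)c1`: 8000 nM

Compound 2 sits level with the other two in this assay, since its value lies within the scatter of both. The three compounds share atoms and bonds and differ only in configuration as drawn. The measured steps are a 1.5-fold lower number from compound 1 to compound 2 (0.18 log units; within the scatter), a 1.3-fold lower number from compound 1 to compound 3 (0.11 log units; within the scatter) and a 1.2-fold higher number from compound 2 to compound 3 (0.07 log units; within the scatter), all within the scatter. Inverting one or both stereocentres therefore shows no measurable effect here.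

The next compound, compound 4 `CC1=NN(c2ccccc2)C(=O)[C@@]12C(=O)C=CC[C@@H]2c1ccccc1`, keeps the configuration of compound 2 but has hydrogen in place of methyl on an aromatic carbon, meta to a large group: 3-methylphenyl to phenyl (hydrogen in place of methyl on an aromatic carbon). Going by the values given here, no measured step covers this kind of change, so the series gives no direct size for it. Among the compounds with values here, the only guide is the narrow spread of the series, seen in a 1.5-fold lower number from compound 1 to compound 2 (0.18 log units; within the scatter), and this is weak support. No step beyond the scatter is expected, and the direction is left open. The estimate corresponds to an expected 1.2-fold higher number from compound 2 to compound 4 (0.07 log units; within the scatter). For compound 4 the estimated value is 8000 nM, with an expected range of 3500 nM to 18000 nM.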

Compound 4, half-maximal inhibitory concentration: 9310 nM
Compound 4: the middle estimate sits 1.2-fold (0.07 log units) below what was measured; the range from low to high includes it.
By their numbers in this assay, from the lowest: compounds 2, 3, 4 and 1 (each within the scatter of the next).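

In this assay, replacing methyl with hydrogen on the aromatic carbon, meta to a large group, gives a 1.4-fold higher number from compound 2 to compound 4 (0.14 log units; within the scatter). Going by these compounds alone, this is the first measured change to the atoms of the series, as compounds 1, 2 and 3 differ only in configuration, and it shows that with the configuration of compound 2 held, the 3-methylphenyl to phenyl change leaves compound 4 level with compound 2. The methyl group is thus not required to keep the number in this range in this cell read-out, though one pair at one place cannot support a wider rule, and nothing available speaks to a cause for this step.

With only methyl and hydrogen compared at this place, the compounds shown leave open whether a methoxy group, a chlorine atom, an amine or a carboxylic acid meta to the large group would move the number beyond the scatter. They also leave open whether the phenyl analogue of compound 4 stays as insensitive to inverting its stereocentres as the 3-methylphenyl compounds 1, 2 and 3 do.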